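The compounds below may be only part of what the source reports. "The series", "measured", "known", "first", "only" and "open" are said of these compounds alone.

Three compounds share one core and differ only on the aromatic ring. Compound 1 `CCOC(=O)C1=CCCCC1S(=O)(=O)Cc1ccc(Cl)c(Cl)c1` gives 53 nM in a functional assay on RAW264.7 cells (Mus musculus), read by fluorescence; a higher number here means a weaker inhibitor, a lower number a stronger inhibitor. Compound 2 `CCOC(=O)C1=CCCCC1S(=O)(=O)Cc1ccc(F)c(Cl)c1` gives 13 nM in this assay; the step of a 4.1-fold lower number from compound 1 to compound 2 (0.61 log units; beyond the scatter) comes from fluoro in place of chloro on an aromatic carbon. Compound 3 `CCOC(=O)C1=CCCCC1S(=O)(=O)Cc1cccc(Cl)c1F` gives 12 nM in this assay; how the cores of compound 3 and compound 1 differ is not broken down here. Compound 4 `CCOC(=O)C1=CCCCC1S(=O)(=O)Cc1cccc(F)c1F` is not yet measured. It differs from compound 3 by fluoro in place of chloro on an aromatic carbon, the same kind of change as that seen before, though here the place is ortho to a fluoro group and meta to a large group, while before it was ortho to a chloro group and para to a large group. The step expected here, a 1.5-fold lower number from compound 3 to compound 4 (0.18 log units; within the scatter), is smaller than the earlier one, because compound 3 already gives 12 nM and the surroundings of the change are not the same. Compound 4 is expected to give 8 nM, between 3 nM and 25 nM, in this assay.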

Compound 4, half-maximal inhibitory concentration: 100 nM
Compound 4: middle estimate off by 13-fold (1.10 log units), on the low side; measured number above the stated range.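

Fluoro in place of chloro on an aromatic carbon gave an 8.3-fold higher number from compound 3 to compound 4 (0.92 log units; beyond the scatter) in this assay, so the gain seen on the earlier pair did not carry over. The same change ran in opposite directions, and the gap between the two steps lies beyond the scatter: the same change on two cores in this assay, a 4.1-fold lower number (0.61 log units; beyond the scatter) from compound 1 to compound 2 and an 8.3-fold higher number (0.92 log units; beyond the scatter) from compound 3 to compound 4, 34-fold (1.53 log units) apart, beyond the scatter of two such steps

This shows that, in this series, the outcome of this change on one core cannot be assumed for another, but two pairs do not show what in the surroundings sets its direction. The compounds shown leave open how a methyl, methoxy or trifluoromethyl group at this place would compare. Going by these compounds, all four carry the ethyl ester, so how a carboxylic acid or an amide in its stead would behave also remains open.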